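Capping a Phenol: From Compound 1 to Compound 3

The compounds below may be only part of what the source reports. "The series", "measured", "known", "first", "only" and "open" are said of these compounds alone.

Compound 1 `O=C(Nc1cccc(-n2cc(-c3ccncc3)c(-c3cc(O)cc(Cl)c3)n2)c1)Nc1ccc(Cl)c(C(F)(F)F)c1` was tested in a functional assay on 786-0 cells (Homo sapiens) for inhibition, read by sulforhodamine B assay, with a stated time of 48 h, tested at 0.1 uM (a lower number here means a stronger effect, a higher number a weaker effect of the compound at the concentration tested), where compound 1 gives 95%. For the measured compounds named here, only one other compound was measured alongside it, compound 2 `O=C(Nc1cccc(-n2cc(-c3ccncc3)c(-c3cc(O)cc(Cl)c3)n2)c1)Nc1ccc(Cl)c(Cl)c1`, which in this assay gives 90%, so the two numbers sit within the usual scatter of each other. Going by the values given here, the only measured step, a number 5 percentage points lower from compound 1 to compound 2 (within the scatter), is the change methyl in place of hydrogen on an oxygen on an aromatic ring nowhere touches: it swaps a group on the urea end of the molecule, not on the phenol. Compound 3 `COc1cc(Cl)cc(-c2nn(-c3cccc(NC(=O)Nc4ccc(Cl)c(C(F)(F)F)c4)c3)cc2-c2ccncc2)c1` differs from compound 1 by methyl in place of hydrogen on an oxygen on an aromatic ring. Among the compounds with values here, no measured step bears on this change, so the expectation rests on the observation that the one step seen left the read-out essentially unchanged. Compound 3 is therefore expected to give 88%, within a range of 60% to 105%, a step estimated as a number 7 percentage points lower from compound 1 to compound 3 (within the scatter).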

Compound 3, a percentage reported as activity, at one concentration (the size of the read-out at that concentration, not a potency): 96%
Compound 3: the middle estimate sits 8 percentage points below what was measured; the range from low to high includes it.
By their numbers in this assay, from the lowest: compounds 2, 1 and 3 (each within the scatter of the next).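

Replacing hydroxy with methoxy on the 3-chloro-5-hydroxyphenyl group is the first change shown at this position, and in this assay it gives a number 1 percentage points higher from compound 1 to compound 3 (within the scatter) at the single concentration tested. The hydrogen on this oxygen can therefore be exchanged for a methyl with no difference beyond the scatter, something the earlier pair could not show, as those two compounds differ elsewhere in the molecule. Nothing measured here offers a reason for this result.

On these data alone, whether an ethyl or a longer chain on this oxygen, or an amine in place of the hydroxy, would read the same remains open. Also open, as far as these compounds go, is whether methoxy would behave alike with the chloro of compound 2 in place of the trifluoromethyl of compound 3.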